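Aortic relaxation: a cyanoethyl chain in place of isopropyl

The source may report more compounds than this note shows. Statements on the series, on what has been measured and on what is new or still open speak of the compounds shown alone.

Among the compounds with values here, compound 2 `CC(C)c1cnc(-c2nn(Cc3ccccc3F)c3ncccc23)nc1N` gives 207000 nM in a functional assay (aorta) with Oryctolagus cuniculus as the target (a lower number here means a stronger inhibitor, a higher number a weaker inhibitor), the highest of the two numbers measured so far. Its nearest neighbour is compound 1 `OCc1ccc(-c2nn(Cc3c(F)cccc3F)c3ccccc23)o1`, and compound 1 gives 15000 nM. Compound 3 `N#CCCc1cnc(-c2nn(Cc3ccccc3F)c3ncccc23)nc1N` is not yet measured; it differs from compound 2 in one place: 2-cyanoethyl in place of isopropyl on an aromatic carbon. Within the data shown here, no measured pair shows this change, so its effect is unknown. A step from compound 2 to compound 3 of a 1.4-fold lower number from compound 2 to compound 3 (0.14 log units; within the scatter) is expected, not beyond the scatter in either direction. For compound 3 a value of 150000 nM is therefore estimated, within 40000 nM to 600000 nM.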

Compound 3, half-maximal inhibitory concentration: 412000 nM
Compound 3: middle estimate off by 2.7-fold (0.44 log units), on the low side; low and high end bracket the measured number.
By their numbers in this assay, from the lowest: compound 1; then compounds 2 and 3 (each within the scatter of the next).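

In this assay, the change of isopropyl to 2-cyanoethyl on this aromatic carbon, ortho to an amino group, gives a 2.0-fold higher number from compound 2 to compound 3 (0.30 log units; within the scatter). This position therefore accepts a chain with one more heavy atom and a hydrogen-bond acceptor without a change that can be told from the scatter. Nothing available bears on the reason for this result.

Both compounds sit at the weak end of the numbers in hand. On these data alone, whether an amine, a carboxylic acid or a longer chain on this carbon would shift the number beyond the scatter remains open.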